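Truncating the isothiocyanate tether on the shared core

This account rests on a few compounds, and the source may have more. Where it says the series, first, only, none or still open, it means among the compounds named here.

Measured so far:
compound 1 `CN(C)C(=O)c1cc2cnc(Nc3ccc(S(=O)(=O)NCCCN=C=S)cc3)nc2n1C1CCCC1`: 41.3%
compound 2 `CN(C)C(=O)c1cc2cnc(Nc3ccc(NC(=O)CCCN=C=S)cc3)nc2n1C1CCCC1`: 39.7%

Going by the values given here, in a functional assay on NCI-H1299 cells (Homo sapiens) for inhibition, read by CCK-8 assay, with a stated time of 72 h, tested at 1 uM (a lower number here means a weaker effect, a higher number a stronger effect of the compound at the concentration tested), compound 1 gives 41.3% and compound 2 gives 39.7%; compound 2 sits within the scatter of the only other number, that of compound 1. Among the compounds with values here, the one measured step, a number 1.6 percentage points lower from compound 1 to compound 2 (within the scatter), shows that swapping the linker made no difference beyond the scatter. Compound 3 `CN(C)C(=O)c1cc2cnc(Nc3ccc(N=C=S)cc3)nc2n1C1CCCC1` differs from compound 2 by a group of 3 heavy atoms (1 carbon, 1 nitrogen, 1 sulfur; no ring) in place of a group of 9 heavy atoms (5 carbon, 2 nitrogen, 1 oxygen, 1 sulfur; no ring), on an aromatic carbon. Within the data shown here, no measured step removes the linker outright, so that step offers only weak guidance. Compound 3 is expected to give 35% (range 15% to 55%), an estimated step of a number 4.7 percentage points lower from compound 2 to compound 3 (within the scatter), within the scatter.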

Compound 3, a percentage reported as inhibition, at one concentration (the size of the read-out at that concentration, not a potency): 46.9%
For compound 3 the middle estimate is 11.9 percentage points below the measured one; the measured number falls inside the stated range.
By their numbers in this assay, from the lowest: compounds 2, 1 and 3 (each within the scatter of the next).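

In this assay, cutting the chain back to the group of 3 heavy atoms on the aromatic carbon leaves the read-out within the scatter, a number 7.2 percentage points higher from compound 2 to compound 3 (within the scatter) and a number 5.6 percentage points higher from compound 1 to compound 3 (within the scatter). At this position, para to a large group, neither chain shown is therefore needed to keep the effect at the concentration tested. From the compounds shown here alone, whether an amine or a carboxylic acid in place of the isothiocyanate would keep this effect remains open, as does the outcome with a longer chain. Nothing available bears on the reason for this result.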